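Swapping Bromine for Nitro on a Chalcone Arm

The source may report more compounds than this note shows. Statements on the series, on what has been measured and on what is new or still open speak of the compounds shown alone.

Of the compounds shown here, three built on a shared core have been tested in a functional assay on PC-3 cells (Homo sapiens) for antiproliferative activity, read by MTT assay, with a stated time of 72 h; a higher number here means a weaker inhibitor, a lower number a stronger inhibitor. Compound 1, `O=C(COc1ccc(C(=O)/C=C/c2ccccc2Br)cc1)N[C@H]1CCOC1=O`, gives 3260 nM in this assay, the lower of the two numbers obtained. Compound 3, `CC(=O)c1ccc(OCCSC(=S)N[C@H]2CCOC2=O)cc1`, gives 46900 nM, a clearly higher number whose distance from compound 1 lies beyond the usual scatter of this assay. Compound 2, `Cc1cc(Cl)ccc1NCC(=O)N[C@H]1CCOC1=O`, gives > 64000 nM, which is a limit of the assay rather than a number. That value is the limit of > 64000 nM in this assay, at which 1 of the 3 values shown sits.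

Compound 4, `O=C(COc1ccc(C(=O)/C=C/c2cccc([N+](=O)[O-])c2)cc1)N[C@H]1CCOC1=O`, has not yet been measured. It differs from compound 1 in one place: 3-nitrophenyl in place of 2-bromophenyl on a double-bonded chain carbon bound to a double-bonded chain carbon. Among the measured compounds shown here, no two measured compounds differ by a single change, so the size of this step cannot be read from the measured set. Given that compound 1 sits at 3260 nM, the expected step of a 1.2-fold higher number from compound 1 to compound 4 (0.09 log units; within the scatter) is small, leaning if anything toward a slightly higher number, and may well fall within the scatter. Compound 4 is therefore expected to give about 4000 nM in this assay, within a range from 1200 nM to 15000 nM.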

Compound 4, half-maximal inhibitory concentration: 56300 nM
For compound 4 the middle estimate is 14-fold (1.15 log units) below the measured one, and the stated range ends below it.
By their numbers in this assay, from the lowest: compound 1; then compounds 3 and 4 (each within the scatter of the next). At a limit, above all of these: compound 2.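

In this assay, 3-nitrophenyl in place of 2-bromophenyl on a double-bonded chain carbon bound to a double-bonded chain carbon gives a 17-fold higher number from compound 1 to compound 4 (1.24 log units; beyond the scatter). Among the compounds shown here, this is the first comparison in the set in which only one place changes, and it shows that the aromatic group at this place has a large effect on the reading, even with the rest of the molecule unchanged. The step has a limit of its own, however: as the two group names show, the substituent and its number on the ring change together, so this single comparison cannot separate the effect of replacing bromine with nitro from the effect of moving the substituent.

The compounds shown leave open how a plain phenyl ring, or a ring carrying an amine or a carboxylic acid, would read at this place, and whether any such group could give a lower number than compound 1 does. The measurements shown also offer nothing that would explain the size of this step.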